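Swapping a benzyl arm for 2-isopropylphenyl on the core

A few compounds are considered here, and "the series" means these few. Any claim that something is new, unique, unknown or untested is made for them only; others in the source may bear on it.

Among the measured compounds shown here, compound 3 `CN1CCN(c2ccc(Nc3ncc(Cl)c(NCc4ccccc4)n3)nc2)CC1` gives 17300 nM in a functional assay on MCF7 cells (Homo sapiens) for inhibition, read by CCK-8 assay, with a stated time of 48 h (a higher number here means a weaker inhibitor of growth, a lower number a stronger inhibitor of growth), the lowest of the two plain numbers measured so far. Compound 1 `Cc1ccccc1Nc1nc(Nc2cccnc2)ncc1Cl` gives 56500 nM in this assay. Compound 2 `Cc1ccccc1Nc1nc(NCc2ccncc2)ncc1Cl` reaches only a limit, > 100000 nM, which is the limit of > 100000 nM in this assay, at which 1 of the 3 values shown sits. The change to compound 4 `CC(C)c1ccccc1Nc1nc(Nc2ccc(N3CCN(C)CC3)cn2)ncc1Cl` is 2-isopropylphenyl in place of benzyl on a nitrogen on an aromatic ring. For the measured compounds named here, no measured step matches this exactly; the nearest is an at least 1.7-fold higher number from compound 1 to compound 2 (0.24 log units; that floor lies within the scatter), where the (pyridin-4-yl)methyl arm gave the higher number, while compound 1 carries an aryl directly on that nitrogen, as compound 4 will. Compound 4 is therefore expected to give a lower number, with a 3.5-fold lower number from compound 3 to compound 4 (0.54 log units; beyond the scatter). The estimate for compound 4 is 5000 nM, within 1000 nM to 25000 nM.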

Compound 4, concentration for 50% growth inhibition: 4360 nM
The estimate for compound 4 lay 1.1-fold (0.06 log units) above the measured number; the range from low to high includes it.
By their numbers in this assay, from the lowest: compound 4; then compound 3; then compound 1. At a limit, above all of these: compound 2.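

In this assay, among the compounds shown here, the change on this nitrogen gives a 4.0-fold lower number from compound 3 to compound 4 (0.60 log units; beyond the scatter) with the rest of the molecule unchanged, the first step here with a plain number at both ends and a size beyond the scatter. So the group on this nitrogen alone can shift growth inhibition. Nothing measured here explains the direction of that shift.

The compounds shown leave open whether the isopropyl group or the ring attached directly to the nitrogen matters more, and what a plain phenyl, a cyclohexyl or a longer chain would give there.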